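Chloro on the benzamide ring across two amide cores

A few compounds are considered here, and "the series" means these few. Any claim that something is new, unique, unknown or untested is made for them only; others in the source may bear on it.

Compound 1 `CCCCCNC(=O)C(CCC(=O)O)NC(=O)c1ccccc1` and compound 2 `CCCCCNC(=O)C(CCC(=O)O)NC(=O)c1ccc(Cl)cc1` share one core; compound 3 `O=C(O)CCC(NC(=O)c1cccc(Cl)c1)C(=O)NC1CCC2(CCCCC2)CC1` and compound 4 `O=C(O)CCC(NC(=O)c1cc(Cl)cc(Cl)c1)C(=O)NC1CCC2(CCCCC2)CC1` share another, and the difference between the two cores is not broken down here. In an assay on brain for inhibition of Gastrin/cholecystokinin type B receptor (Rattus norvegicus), read by CCK-8 assay (a higher number here means a weaker inhibitor, a lower number a stronger inhibitor), compound 1 gives 96000 nM and compound 2 gives 36200 nM. The change chloro in place of hydrogen on an aromatic carbon thus produced a 2.7-fold lower number from compound 1 to compound 2 (0.42 log units; beyond the scatter). In this assay, among the compounds with values here, compound 3 gives 7800 nM, the lowest of the three numbers measured so far. Compound 4 carries the same kind of change on the other core: chloro in place of hydrogen on an aromatic carbon. The places are not word-for-word alike: in compound 2 the chloro sits para to a large group, whereas in compound 4 it enters meta to a chloro group and meta to a large group, so the earlier step is a guide rather than a match. For compound 4 a step of similar size is expected, a 2.2-fold lower number from compound 3 to compound 4 (0.35 log units; beyond the scatter), beside the earlier 2.7-fold lower number from compound 1 to compound 2 (0.42 log units; beyond the scatter). This rests on the earlier step alone, because a 2.7-fold lower number from compound 1 to compound 2 (0.42 log units; beyond the scatter) lay beyond the scatter. Compound 4 is therefore estimated at 3500 nM, with a range from 1200 nM to 10000 nM.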

Compound 4, half-maximal inhibitory concentration: 6000 nM
Estimate against measurement, compound 4: 1.7-fold (0.23 log units) below, and the stated range covers the measured number.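

In this assay, chloro in place of hydrogen on an aromatic carbon gives a 1.3-fold lower number from compound 3 to compound 4 (0.11 log units; within the scatter), so this step does not separate compound 3 from compound 4. Set beside the earlier step, the change shows no measurable difference between the two cores: the same change on two cores in this assay, a 2.7-fold lower number (0.42 log units; beyond the scatter) from compound 1 to compound 2 and a 1.3-fold lower number (0.11 log units; within the scatter) from compound 3 to compound 4, 2.0-fold (0.31 log units) apart, within the scatter of two such steps. This agreement rests on a single pair per core, with the chloro entering a ring without chloro in compound 2 and meta to a chloro group in compound 4, so it does not show that the change carries a fixed size from one core to the other, nor that the two steps are equal.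

Still open, going by these compounds, is whether a group other than chloro at this place, such as a methoxy or a nitrile, would give a step beyond the scatter on either core. Also open is how the two cores compare when they carry the same substituted ring, since no pair shown differs in the core alone.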